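This account rests on a few compounds, and the source may have more. Where it says the series, first, only, none or still open, it means among the compounds named here.

In a functional assay on BT-20 cells (Homo sapiens) for cytotoxicity, read by MTT assay, with a stated time of 68 h (on this read-out lower numbers stand for stronger inhibition and higher numbers for weaker inhibition), two compounds sharing one core have been measured so far. Compound 1 `O=C(/C=C/c1cccc(OCc2ccccc2)c1)c1ccc([N+](=O)[O-])cc1` gives 80900 nM, while compound 2 `O=C(/C=C/c1cccc(OCc2ccccc2)c1)c1ccc(Cl)c(Cl)c1Cl` gives 3900 nM, the lower of the two numbers. Compound 3 `COc1ccc(C(=O)/C=C/c2cccc(OCc3ccccc3)c2)cc1` awaits measurement and differs from compound 2 at one place, on a carbonyl carbon: 4-methoxyphenyl in place of 2,3,4-trichlorophenyl on a carbonyl carbon. Among the measured compounds shown here, one measured step bears on this change, a 21-fold lower number from compound 1 to compound 2 (1.32 log units; beyond the scatter), a large step at the same place. For the measured compounds named here, it shows that the group on the carbonyl carbon can shift the number widely in this assay, but no measured compound carries 4-methoxyphenyl. With compound 2 holding the lowest number at 3900 nM, a moderate rise is expected, smaller than that measured step. The expected step is a 3.8-fold higher number from compound 2 to compound 3 (0.59 log units; beyond the scatter). Compound 3 is estimated at 15000 nM, with an expected range from 4000 nM to 60000 nM.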

Compound 3, half-maximal inhibitory concentration: 38300 nM
Compound 3: the middle estimate sits 2.6-fold (0.41 log units) below what was measured; low and high end bracket the measured number.
By their numbers in this assay, from the lowest: compound 2; then compound 3; then compound 1.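

With 4-methoxyphenyl in place of 2,3,4-trichlorophenyl on a carbonyl carbon, this assay records a 9.8-fold higher number from compound 2 to compound 3 (0.99 log units; beyond the scatter), so a second group at this place also stays well short of compound 2. Methoxy in place of nitro on an aromatic carbon gives a 2.1-fold lower number from compound 1 to compound 3 (0.32 log units; beyond the scatter), a much smaller shift than the one from 4-nitrophenyl to 2,3,4-trichlorophenyl, and compound 2 keeps the lowest of the three numbers. Nothing at hand explains why these groups rank as they do.

The compounds shown leave open whether all three chlorines are needed for the low number of compound 2, which a phenyl carrying a single chlorine would test, and how an amine would read at the place of methoxy or nitro. As far as these compounds go, all three compounds also share the rest of the core, so the effect of any change outside this place remains unknown.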